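Isopropyl in Place of Nitro: Compound 1 to Compound 4

This account rests on a few compounds, and the source may have more. Where it says the series, first, only, none or still open, it means among the compounds named here.

Compound 1 `Cc1cccc(Cn2c(CN3CCN(C(=O)c4ccc([N+](=O)[O-])cc4)CC3)nc3ccccc32)c1` has the lowest number of three measured compounds in an assay on isolated protein for inhibition of aldehyde dehydrogenase 1A1 (Homo sapiens), read by spectrophotometry, tested at 10 uM (on this read-out higher numbers stand for more inhibition at the one concentration tested (going by the name of the read-out) and lower numbers for less inhibition), where compound 1 gives 24.3%. Compound 3 `Cc1ccc(Cn2c(CN3CCN(C(=O)C4CC4)CC3)nc3ccccc32)cc1` gives 51.5%, and compound 2 `Cc1cccc(Cn2c(OC3CCN(C(=O)c4ccco4)CC3)nc3ccccc32)c1` gives 68.3%; both gaps to compound 1 lie beyond the usual scatter. Compound 4 `Cc1cccc(Cn2c(CN3CCN(C(=O)c4ccc(C(C)C)cc4)CC3)nc3ccccc32)c1` has not yet been measured. It differs from compound 1 in one place: isopropyl in place of nitro on an aromatic carbon. Among the measured compounds shown here, no pair of measured compounds differs in only one place, so no directly comparable step exists. Compound 2 and compound 3 both lack a nitro group and both score higher than compound 1, yet they differ elsewhere too, so the size of the step is uncertain. A moderate rise is expected, estimated as a number 17.7 percentage points higher from compound 1 to compound 4 (beyond the scatter). Compound 4 is expected to give 42%, within a range from 20% to 64%.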

Compound 4, a percentage reported as inhibition, at one concentration (the size of the read-out at that concentration, not a potency): 67.6%
Compound 4: middle estimate off by 25.6 percentage points, on the low side; the whole stated range lies below it.
By their numbers in this assay, from the lowest: compound 1; then compound 3; then compounds 4 and 2 (each within the scatter of the next).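

In this assay, among the compounds shown here, the change from 4-nitrophenyl to 4-isopropylphenyl gives a number 43.3 percentage points higher from compound 1 to compound 4 (beyond the scatter) and is the first comparison here that isolates a single place. It shows that this one group on the aromatic ring can by itself move the read-out well beyond the scatter. Nitro and isopropyl have equal heavy-atom counts, but only nitro carries hydrogen-bond acceptors, and no measurement shown explains the rise. Still open, as far as these compounds go, is whether losing nitro or gaining isopropyl matters more, which a plain hydrogen or an amine there could help separate. From the compounds shown here alone, whether the step holds with the other compounds' cores also remains open.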